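The compounds below may be only part of what the source reports. "The series", "measured", "known", "first", "only" and "open" are said of these compounds alone.

Compound 1 `CC/N=C(\S)NCCCCCCn1nc(-c2ccccc2)ccc1=O` is the thiourea of this pair and the starting point of the step followed here. Within the data shown here, in a functional assay on the whole organism with Rattus norvegicus as the target, at a dose of 100 mg/kg (on this read-out lower numbers stand for less inhibition and higher numbers for more inhibition at the one dose given (going by the name of the read-out)), compound 1 gives -5.6%, the lowest of the two numbers known, and its nearest neighbour is compound 2 `CC/N=C(/NC#N)NCCCCCn1nc(-c2ccccc2)ccc1=O`, which in this assay gives 48.2%. Among the measured compounds shown here, the one measured step, a number 53.8 percentage points higher from compound 1 to compound 2 (beyond the scatter), already swaps the thiourea for a cyanoguanidine while shortening the chain by one carbon. Compound 3 `C/N=C(\NC#N)NCCCCn1nc(-c2ccccc2)ccc1=O` goes one step further along the same line: a group of 7 heavy atoms (3 carbon, 4 nitrogen; no ring) in place of a group of 8 heavy atoms (5 carbon, 2 nitrogen, 1 sulfur; no ring), on a saturated chain carbon, four bonds along the chain from an aromatic nitrogen. For the measured compounds named here, the change to compound 2 bears directly on this step, since it shares the cyanoguanidine, but the further shortening of the chain has no measured counterpart. An increase in this assay is therefore expected for compound 3, estimated as a number 40.6 percentage points higher from compound 1 to compound 3 (beyond the scatter). For compound 3 the estimate in this assay is 35%, with a range from 5% to 60%.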

Compound 3, a percentage reported as inhibition, in the whole organism at one dose (the size of the read-out at that dose, not a potency): 79%
For compound 3 the middle estimate is 44 percentage points below the measured one; measured number above the stated range.
By their numbers in this assay, from the lowest: compound 1; then compound 2; then compound 3.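

In this assay, the change on a saturated chain carbon, four bonds along the chain from an aromatic nitrogen, gives a number 84.6 percentage points higher from compound 1 to compound 3 (beyond the scatter). This shows that a large gain over the thiourea compound 1 is not confined to a single cyanoguanidine compound: it also appears with a shorter chain and with methyl in place of ethyl on the end group. No data are available that explain the size of this step.

The compounds shown leave open how much of the step belongs to the end group and how much to the chain length, as these change together. They also leave open how a urea or a plain amine would read at this position, and how the cyanoguanidine would read on a longer chain.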